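Methoxy in place of a carbamate on the shared core

The source may hold more compounds than are shown below. What is called first, only, known or untested is meant among the compounds shown, and "the series" means these compounds.

Measured so far:
compound 1 `COc1ccc(-c2ccc(Cc3ccncc3)cc2)cc1F` — 3340 nM
compound 2 `CC(C)(C)OC(=O)Nc1ccc(-c2ccc(Cc3ccncc3)cc2)cc1NC(=O)OC(C)(C)C` — > 10000 nM

In an assay for inhibition of steroid 17-alpha-hydroxylase/17,20 lyase (Homo sapiens) (a higher number here means a weaker inhibitor, a lower number a stronger inhibitor), compound 1 gives 3340 nM. For compound 2 the result is only a limit of this assay, > 10000 nM, so compound 2 sits at the limit of > 10000 nM in this assay, at which 1 of the 2 values shown sits, and no number for it is known. Compound 3 `COc1ccc(-c2ccc(Cc3ccncc3)cc2)cc1NC(=O)OC(C)(C)C` is not yet measured in this assay. Compared with compound 2, the change is methoxy in place of (tert-butoxycarbonyl)amino on an aromatic carbon. Among the compounds with values here, no measured step covers this change; a move from the limit toward the range of compound 1 is expected, and the step from compound 2 to compound 3 is estimated as an at least 2.0-fold lower number from compound 2 to compound 3 (0.30 log units; that floor lies within the scatter). Compound 3 is expected at 5000 nM, between 1500 nM and 15000 nM.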

Compound 3, half-maximal inhibitory concentration: > 10000 nM
Compound 3 ended at the assay's limit (the forecaster's own chance of this, stated with the estimate: 25%); middle value at least 2.0-fold (0.30 log units) from the limit.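

In this assay compound 3, with methoxy in place of one (tert-butoxycarbonyl)amino group, still gives only a limit and not a number: the limit of > 10000 nM in this assay, at which 2 of the 3 values shown sit. The step between the two limit compounds cannot be read. Putting (tert-butoxycarbonyl)amino in place of fluoro gives an at least 2.9-fold higher number from compound 1 to compound 3 (0.47 log units; beyond the scatter), so on this core a single (tert-butoxycarbonyl)amino group is enough to keep the value at the limit.

Open, on these data alone, is whether a free amine or an acetamide at this place would bring the value back toward that of compound 1.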